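The source may hold more compounds than are shown below. What is called first, only, known or untested is meant among the compounds shown, and "the series" means these compounds.

Measured so far:
- Compound 1, `CC(C)C(NC(=O)c1ccc(C(=N)N)cc1)C(C)(C)C(=O)N1CCC(CC(=O)O)CC1`: 0.8 h
- Compound 2, `CCCCCC(NC(=O)c1ccc(C(=N)N)cc1)C(C)(C)C(=O)N1CCC(CC(=O)O)CC1`: 0.517 h

Going by the values given here, in an in vivo ADME assay on the whole organism (Cavia porcellus) (a higher number here means that the compound lasts longer, a lower number that the compound disappears faster), compound 1 gives 0.8 h, the higher of the two numbers measured so far. Its nearest neighbour is compound 2, and the step of a 1.5-fold lower number from compound 1 to compound 2 (0.19 log units; within the scatter) is too small to count as a real difference, so the two compounds behave alike in this assay.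

Compound 3, `CC(C)(C(=O)N1CCC(CC(=O)O)CC1)C(NC(=O)c1ccc(C(=N)N)cc1)c1cccc(O)c1`, has not yet been measured. It differs from compound 1 by 3-hydroxyphenyl in place of isopropyl on a saturated chain carbon bound to an amide-type nitrogen and a saturated chain carbon.

Among the compounds with values here, only one measured step bears on this position in the molecule: a 1.5-fold lower number from compound 1 to compound 2 (0.19 log units; within the scatter), which swapped one hydrocarbon chain for a longer one and stayed within the scatter. Within the data shown here, no measured step introduces an aromatic ring or a hydroxyl group at this place, so there is no direct guide to how the new 3-hydroxyphenyl group will behave in this assay. Among the measured compounds shown here, with the single comparison at this position showing no change, a step of no more than the scatter is expected in either direction.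

Compound 3 is therefore expected to give 0.7 h, with a range of 0.3 h to 1.6 h, which means an expected step of a 1.1-fold lower number from compound 1 to compound 3 (0.06 log units; within the scatter).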

Compound 3, half-life: 1.08 h
The estimate for compound 3 lay 1.5-fold (0.19 log units) below the measured number; the measured number falls inside the stated range.
By their numbers in this assay, from the lowest: compounds 2, 1 and 3 (each within the scatter of the next, the first and the last beyond it).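

In this assay, the saturated chain carbon bound to an amide-type nitrogen and a saturated chain carbon can carry an aromatic ring with a hydroxyl group as well as a hydrocarbon chain: putting 3-hydroxyphenyl in place of isopropyl gives a 1.4-fold higher number from compound 1 to compound 3 (0.13 log units; within the scatter) and so leaves the half-life effectively unchanged. Going by these compounds alone, measured against the pentyl group, the same ring gives a 2.1-fold higher number from compound 2 to compound 3 (0.32 log units; beyond the scatter) and is the first step at this position to pass the scatter, although it is modest and compound 1 lies within the scatter of both neighbours, so the three compounds do not form a clear trend. No measured information explains why these groups differ, so the result can only be described.

The compounds shown do not separate the contribution of the aromatic ring from that of its hydroxyl group, a question that a plain phenyl group at this place would help to settle. Going by these compounds, it also remains open how an amine or a carboxylic acid on that ring, or a chain of a different kind at this position, would affect the half-life in this assay on the shared core.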